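Chloro to Bromo: a Small Step Measured Twice

The compounds below may be only part of what the source reports. "The series", "measured", "known", "first", "only" and "open" are said of these compounds alone.

Three compounds have so far been measured in a functional assay on MGC-803 cells (Homo sapiens) for inhibition, read by MTT assay, with a stated time of 72 h; on this read-out lower numbers stand for stronger inhibition and higher numbers for weaker inhibition:

compound 1, `O=C(CSc1nc(Nc2ccccc2)c2ccccc2n1)Nc1ccccc1Cl`, gives 24800 nM
compound 2, `O=C(CSc1nc(Nc2ccccc2)c2ccccc2n1)Nc1ccccc1Br`, gives 18600 nM
compound 3, `C=CC(=O)Nc1cccc(NC(=O)CSc2nc(Nc3cccc(Cl)c3)c3ccccc3n2)c1`, gives 7830 nM

Compound 1 and compound 2 share a core and differ in a single place: bromo in place of chloro on an aromatic carbon. That exchange produced a 1.3-fold lower number from compound 1 to compound 2 (0.12 log units; within the scatter), so the two numbers cannot be told apart with confidence.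

Compound 3 rests on a different core; how the core of compound 3 differs from the core of compound 1 is not broken down here. Its number is the lowest of the three, and its gaps to compound 2 and to compound 1 both lie beyond the usual scatter of repeated measurements.

Compound 4, `C=CC(=O)Nc1cccc(NC(=O)CSc2nc(Nc3cccc(Br)c3)c3ccccc3n2)c1`, has not yet been measured. It differs from compound 3 in one place: bromo in place of chloro on an aromatic carbon. Among the measured compounds shown here, this is the same kind of change as the one between compound 1 and compound 2, though not the same: there the halogen sits ortho to a large group, here it sits meta to a large group.

For this kind of change a step of a 1.2-fold lower number from compound 3 to compound 4 (0.08 log units; within the scatter) is expected, resting on the earlier exchange, which gave a 1.3-fold lower number from compound 1 to compound 2 (0.12 log units; within the scatter). On that basis compound 4 is estimated at 6500 nM, with a plausible range from 3000 nM to 14000 nM.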

Compound 4, half-maximal inhibitory concentration: 11900 nM
The estimate for compound 4 lay 1.8-fold (0.26 log units) below the measured number; the measured number falls inside the stated range.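

In this assay, among the compounds shown here, placing bromo where chloro stood on the core of compound 3 gave a 1.5-fold higher number from compound 3 to compound 4 (0.18 log units; within the scatter), so on this second core, as on the first, the exchange produces no step that can be told apart from repeat-to-repeat variation. Set side by side, the two steps also cannot be separated from each other: the same change on two cores in this assay, a 1.3-fold lower number (0.12 log units; within the scatter) from compound 1 to compound 2 and a 1.5-fold higher number (0.18 log units; within the scatter) from compound 3 to compound 4, 2.0-fold (0.31 log units) apart, within the scatter of two such steps. This shows that, across these two pairs, the exchange of one halogen for the other carried from one core to the other without a measurable effect on the number, but it does not show that the two cores respond identically, nor does it give the exchange a direction, since two small steps within the scatter can hide a real small effect, and the halogen does not sit in the same place in the two pairs.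

The compounds shown leave open whether a group of a different kind in the place of the halogen, such as an amine, a carboxylic acid or a methoxy group, would move the number beyond the scatter, and whether fluoro would behave as chloro and bromo do. They also leave open which of the several differences between the core of compound 1 and the core of compound 3 lies behind the gap between those two compounds.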